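Ester Analogues of a Pyrrole Vitamin D Receptor Agonist

The source may report more compounds than this note shows. Statements on the series, on what has been measured and on what is new or still open speak of the compounds shown alone.

Measured compounds:
Compound 1, `CCn1c(C(=O)NCCN(C)C)ccc1C(CC)(CC)c1ccc(OCC(O)C(C)(C)C)c(C)c1`: 14 nM in an assay on HL-60 cells for agonist activity at vitamin D3 receptor (Homo sapiens), read by microscopy, with a stated time of 96 h; a higher number here means that more compound is needed for the effect, a lower number that less compound is needed
Compound 2, `CCOc1ccc(NC(=O)c2ccc(C(CC)(CC)c3ccc(OCC(O)C(C)(C)C)c(C)c3)n2CC)cc1`: 630 nM
Compound 3, `CCOC(=O)c1ccc(OC(=O)c2ccc(C(CC)(CC)c3ccc(OCC(O)C(C)(C)C)c(C)c3)n2CC)cc1`: > 50000 nM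

Compound 3 sits at the assay limit (the limit of > 50000 nM in this assay, at which 1 of the 3 values shown sits), so only a bound is known for it. Compound 4, `CCn1c(C(=O)OCc2ccccn2)ccc1C(CC)(CC)c1ccc(OCC(O)C(C)(C)C)c(C)c1`, differs from it by (pyridin-2-yl)methyl in place of 4-(ethoxycarbonyl)phenyl on an oxygen next to a carbonyl group. Among the compounds with values here, no measured step compares two esters; the steps that bear on this change are an at least 3500-fold higher number from compound 1 to compound 3 (3.55 log units; beyond the scatter) and an at least 79-fold higher number from compound 2 to compound 3 (1.89 log units; beyond the scatter), both large losses on moving to the ester. The shared core and both ester-type carbonyls stay, so compound 4 is expected to remain weak, with an expected step of an at least 2.0-fold lower number from compound 3 to compound 4 (0.30 log units; that floor lies within the scatter). For compound 4 the estimate is 25000 nM, ranging from 3000 nM to 50000 nM.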

Compound 4, half-maximal effective concentration: > 50000 nM
Compound 4: only a limit was reported; the forecaster's own chance of this, stated with the estimate: 50%; middle value at least 2.0-fold (0.30 log units) away from the limit.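

In this assay compound 4 gives only a limit, as does compound 3, so the step between these two esters cannot be read: the limit of > 50000 nM in this assay, at which 2 of the 4 values shown sit.

The result still adds something, since (pyridin-2-yl)methyl in place of 4-(ethoxycarbonyl)phenyl on an oxygen next to a carbonyl group does not bring back a readable value. The loss against the amides therefore also holds for this second ester, with an at least 79-fold higher number from compound 2 to compound 4 (1.89 log units; beyond the scatter) and an at least 3500-fold higher number from compound 1 to compound 4 (3.55 log units; beyond the scatter).

As far as these compounds go, whether a plain ethyl ester or a carboxylic acid on this carbonyl carbon would give a readable value remains open.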